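A few compounds are considered here, and "the series" means these few. Any claim that something is new, unique, unknown or untested is made for them only; others in the source may bear on it.

Compound 1, `O=C(CBr)Nc1ccc(C(=O)/C=C/c2ccc(Cl)cc2)cc1`: in a functional assay on the whole organism (strain albino) for inhibition, with Rattus norvegicus as the target, read by paw edema, with stated times of 30 min and 4 h, at a dose of 100 mg/kg by the oral route (on this read-out higher numbers stand for more inhibition at the one dose given (going by the name of the read-out) and lower numbers for less inhibition), compound 1 gives 59%.
Compound 2, `COc1ccc(/C=C/C(=O)c2ccc(NC(=O)CBr)cc2)cc1`: in this assay compound 2 gives 41%.
Compound 3, `O=C(CO[N+](=O)[O-])Nc1ccc(C(=O)/C=C/c2ccc(Cl)cc2)cc1`: in this assay compound 3 gives 67%.

Among these three numbers compound 3 stands highest, but its gap to compound 1 is within the scatter, while its gap to compound 2 is beyond it. The two measured steps are a number 8 percentage points higher from compound 1 to compound 3 (within the scatter), which is within the scatter, and a number 18 percentage points lower from compound 1 to compound 2 (beyond the scatter), which is beyond it.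

Compound 4, `COc1ccc(/C=C/C(=O)c2ccc(NC(=O)CO[N+](=O)[O-])cc2)cc1`, has not yet been measured in this assay. It differs from compound 3 by one change: methoxy in place of chloro on an aromatic carbon. For the measured compounds named here, this is the same change that was measured between compound 1 and compound 2, and the only step that bears on it is a number 18 percentage points lower from compound 1 to compound 2 (beyond the scatter). Compound 3 differs from compound 1 only by nitrooxy in place of bromo, a change that moved the number little, as a number 8 percentage points higher from compound 1 to compound 3 (within the scatter) shows, so the same downward step of about the same size is expected from compound 3 to compound 4.

Compound 4 is therefore estimated to give about 49%, within a range from 35% to 62%, which means an expected step of a number 18 percentage points lower from compound 3 to compound 4 (beyond the scatter).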

Compound 4, a percentage reported as inhibition, in the whole organism at one dose (the size of the read-out at that dose, not a potency): 51%
Beside the measured number, compound 4's estimate is 2 percentage points below it; the measured number falls inside the stated range.
By their numbers in this assay, from the lowest: compounds 2, 4, 1 and 3 (each within the scatter of the next, the first and the last beyond it).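

The step from chloro to methoxy on the aromatic carbon has now been read on a second core: in this assay it gives a number 16 percentage points lower from compound 3 to compound 4 (beyond the scatter), so the drop seen with the bromo chain also appears with the nitrooxy chain, at much the same size: the same change on two cores in this assay, a number 18 percentage points lower (beyond the scatter) from compound 1 to compound 2 and a number 16 percentage points lower (beyond the scatter) from compound 3 to compound 4, 2 percentage points apart, within the scatter of two such steps. The exchange of bromo for nitrooxy, so far read only with the 4-chlorophenyl group, now also has a reading with the 4-methoxyphenyl group, a number 10 percentage points higher from compound 2 to compound 4 (within the scatter), and on both cores it stays within the scatter: the same change on two cores in this assay, a number 8 percentage points higher (within the scatter) from compound 1 to compound 3 and a number 10 percentage points higher (within the scatter) from compound 2 to compound 4, 2 percentage points apart, within the scatter of two such steps. Across these four compounds, none of which goes against it, the two changes therefore read as independent of each other, with the step beyond the scatter coming from the aromatic substituent and not from the end of the chain.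

The compounds shown hold only chloro and methoxy at the aromatic carbon, so it remains open how a hydroxy, a dimethylamino or a carboxylic acid group there would read. Each compound is also read at a single dose, which leaves open how the numbers would shift at other doses and gives no potency.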